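Replacing 3-nitrophenyl with 3,4,5-trimethoxyphenyl in compound 3

The compounds below may be only part of what the source reports. "The series", "measured", "known", "first", "only" and "open" are said of these compounds alone.

Of the compounds shown here, three have so far been measured in an ADME assay on L02 cells (Homo sapiens) for cytotoxicity, read by MTT assay, with a stated time of 24 h; on this read-out higher numbers stand for weaker inhibition and lower numbers for stronger inhibition. Compound 1 `CC(=O)Nc1ccc(S(=O)(=O)N2C/C(=C\c3ccccc3F)C(=O)/C(=C/c3ccccc3F)C2)cc1` gives 11600 nM, compound 2 `COc1cc(/C=C2\CN(S(=O)(=O)c3ccc(F)cc3)C/C(=C\c3ccccc3F)C2=O)cc(OC)c1OC` gives 17600 nM, and compound 3 `CC(=O)Nc1ccc(S(=O)(=O)N2C/C(=C\c3cccc([N+](=O)[O-])c3)C(=O)/C(=C/c3ccccc3F)C2)cc1` gives 18400 nM. Compound 3 therefore stands within the scatter of both other compounds, so these numbers do not separate it from either.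

Compound 4 `COc1cc(/C=C2\CN(S(=O)(=O)c3ccc(NC(C)=O)cc3)C/C(=C\c3ccccc3F)C2=O)cc(OC)c1OC` remains unmeasured and differs from compound 3 in one place: 3,4,5-trimethoxyphenyl in place of 3-nitrophenyl on a double-bonded chain carbon bound to a double-bonded ring carbon. Going by the values given here, the only measured step at this kind of place is a 1.6-fold higher number from compound 1 to compound 3 (0.20 log units; within the scatter), in which 3-nitrophenyl replaced 2-fluorophenyl. Among the compounds with values here, that step stayed within the scatter, so the one exchange seen here gives no sign of a large response in this assay. Compound 2 already carries 3,4,5-trimethoxyphenyl at this place and gives 17600 nM, but it differs from compound 4 elsewhere, so it offers a nearby value and not a clean step. On this evidence, no change beyond the scatter is expected, and no direction can be called with confidence. The expected shift is small: a 1.2-fold lower number from compound 3 to compound 4 (0.09 log units; within the scatter). Compound 4 is estimated at 15000 nM, with an expected range of 7500 nM to 30000 nM.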

Compound 4, half-maximal inhibitory concentration: 14000 nM
Beside the measured number, compound 4's estimate is 1.1-fold (0.03 log units) above it; low and high end bracket the measured number.
By their numbers in this assay, from the lowest: compounds 1, 4, 2 and 3 (each within the scatter of the next).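

In this assay, the place on a double-bonded chain carbon bound to a double-bonded ring carbon now carries three different groups on otherwise matched compounds, and both a 1.3-fold lower number from compound 3 to compound 4 (0.12 log units; within the scatter) and a 1.2-fold higher number from compound 1 to compound 4 (0.08 log units; within the scatter) lie within the scatter. So 3,4,5-trimethoxyphenyl cannot be told apart from 3-nitrophenyl or 2-fluorophenyl here, even though it brings more heavy atoms than 3-nitrophenyl and no nitrogen. Going by these compounds alone, the first clean look at a second place, acetamido in place of fluoro on an aromatic carbon, gives a 1.3-fold lower number from compound 2 to compound 4 (0.10 log units; within the scatter) and also stays within the scatter, while no supporting data bear on these results.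

The compounds shown leave open whether any group at the first place can move the number beyond the scatter, for instance a phenyl ring carrying an amine or a carboxylic acid. They also leave open what a different group would do in place of the 2-fluorophenyl that all four compounds share, for instance a simple unsubstituted phenyl or a longer chain.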